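Trimming the side chain of compound 2

The source may hold more compounds than are shown below. What is called first, only, known or untested is meant among the compounds shown, and "the series" means these compounds.

Compound 1 `CCCCCCCCCCc1cc2cn(COCCO)c(O)nc-2n1` gives 32000 nM
Compound 2 `CCCCCCCc1cc2cn(COCCO)c(=O)nc2o1` gives 140000 nM
Compound 3 `CCCCCCCCC#Cc1cc2cn(COCCO)c(=O)nc2o1` gives 42000 nM

In a functional assay on HEL cells (Homo sapiens) (on this read-out higher numbers stand for lower toxicity in this test and lower numbers for higher toxicity in this test), compound 2 (140000 nM) holds the highest number of the three. Compound 3 gives 42000 nM and compound 1 gives 32000 nM. The gaps from compound 2 to each of these two lie beyond the scatter. Compound 4 (`CCCCCc1cc2cn(COCCO)c(=O)nc2o1`) differs from compound 2 in one place, with hydrogen in place of ethyl on a saturated chain carbon, five bonds along the chain from an aromatic carbon. Among the measured compounds shown here, no measured pair isolates this change, so the expectation is loose: a small rise in this assay that probably stays within the scatter. The expected step is modest and upward (a 1.4-fold higher number from compound 2 to compound 4 (0.13 log units; within the scatter)). For compound 4 the estimated value is (190000 nM), with an expected range from (90000 nM) to (400000 nM).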

Compound 4, half-maximal cytotoxic concentration: > 200000 nM
Compound 4 gave a limit, no number (the forecaster's own chance of this, stated with the estimate: 35%); middle value at least 1.0-fold (0.02 log units) away from the limit.
By their numbers in this assay, from the lowest: compounds 1 and 3 (each within the scatter of the next); then compound 2. At a limit, above all of these: compound 4.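

In this assay, compound 4 reads > 200000 nM, which is a limit and not a number. The step is an at least 1.4-fold higher number from compound 2 to compound 4 (0.15 log units; that floor lies within the scatter), so removing ethyl on a saturated chain carbon, five bonds along the chain from an aromatic carbon, did not bring the number down, though the true size of the change cannot be read. This is the first single-place comparison among these compounds, and it gives a floor only.

As far as these compounds go, whether a still shorter chain such as propyl or methyl, or an amine at the chain end, would keep the number this high remains open.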